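A few compounds are considered here, and "the series" means these few. Any claim that something is new, unique, unknown or untested is made for them only; others in the source may bear on it.

Values in a functional assay on LM7 cells (Homo sapiens) for cytotoxicity, read by MTT assay, with a stated time of 72 h; a lower number here means a stronger inhibitor, a higher number a weaker inhibitor:
compound 1 `Cc1nnc(SCc2coc3ccccc3c2=O)o1`: 3500 nM
compound 3 `Nc1nnc(SCc2coc3ccccc3c2=O)s1`: 730 nM
compound 2 `Cc1ccc2oc(CSc3nnc(N)s3)cc(=O)c2c1`: > 25000 nM, which is a limit of the assay and not a number.

From compound 3 to compound 1 the change is 5-methyl-1,3,4-oxadiazol-2-yl in place of 5-amino-1,3,4-thiadiazol-2-yl on a sulfur, and the step is a 4.8-fold higher number from compound 3 to compound 1 (0.68 log units; beyond the scatter). Compound 4 `Cc1ccc2oc(CSc3nnc(C)o3)cc(=O)c2c1` arises from compound 2 by the same change, (5-methyl-1,3,4-oxadiazol-2-yl in place of 5-amino-1,3,4-thiadiazol-2-yl on a sulfur), on the same kind of place. How the core of compound 2 differs from the core of compound 3 is not broken down here. Compound 2 already sits at the limit of > 25000 nM in this assay, at which 1 of the 3 values shown sits. The step from compound 2 to compound 4 in this assay is expected to be of a size like the earlier one, a step that the limit leaves unreadable from compound 2 to compound 4, which rests on a 4.8-fold higher number from compound 3 to compound 1 (0.68 log units; beyond the scatter). Compound 4 is therefore expected most likely to give only a limit again, estimated at 80000 nM, between 25000 nM and 300000 nM.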

Compound 4, half-maximal inhibitory concentration: > 25000 nM
Compound 4: no number, only a limit; the forecaster's own chance of this, stated with the estimate: 90%; the middle value does not contradict the limit.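

Compound 2 and compound 4 each give only a limit of the assay, so no step can be read between them: the limit of > 25000 nM in this assay, at which 2 of the 4 values shown sit. Still open, from the compounds shown here alone, is whether 5-methyl-1,3,4-oxadiazol-2-yl in place of 5-amino-1,3,4-thiadiazol-2-yl changes the number at all on the core of compound 2.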